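Chain Lengthening on a Shared Core, Measured in Cells

The source may hold more compounds than are shown below. What is called first, only, known or untested is meant among the compounds shown, and "the series" means these compounds.

Compound 1 `CC/C=C/C(=O)Nc1cccc(Oc2nc(Nc3ccn(C)n3)nc3c2CSCC3)c1` and compound 2 `CCC/C=C/C(=O)Nc1cccc(Oc2nc(Nc3ccn(C)n3)nc3c2CSCC3)c1` share one core; compound 3 `CC/C=C/C(=O)Nc1cccc(Oc2nc(Nc3ccc(OC)cc3)nc3c2CSCC3)c1` and compound 4 `CCC/C=C/C(=O)Nc1cccc(Oc2nc(Nc3ccc(OC)cc3)nc3c2CSCC3)c1` share another. The two cores differ by 4-methoxyphenyl in place of 1-methyl-1H-pyrazol-3-yl on a nitrogen on an aromatic ring. In a functional assay on HeLa cells (Homo sapiens) for antiproliferative activity, read by MTT assay, with a stated time of 72 h (on this read-out lower numbers stand for stronger inhibition and higher numbers for weaker inhibition), compound 1 gives > 50000 nM, a limit of the assay rather than a number. In this assay compound 2 gives 17000 nM and compound 3 gives 27200 nM. The change from compound 1 to compound 2, (methyl in place of hydrogen on a saturated chain carbon, two bonds along the chain from a double-bonded chain carbon), brought an at least 2.9-fold lower number from compound 1 to compound 2 (0.46 log units; beyond the scatter), while an at least 1.8-fold lower number from compound 1 to compound 3 (0.26 log units; that floor lies within the scatter). The same change, (methyl in place of hydrogen on a saturated chain carbon, two bonds along the chain from a double-bonded chain carbon), now leads from compound 3 to compound 4. Because the earlier step gave an at least 2.9-fold lower number from compound 1 to compound 2 (0.46 log units; beyond the scatter), a step of similar size is expected, a 3.0-fold lower number from compound 3 to compound 4 (0.48 log units; beyond the scatter), though compound 1 sits at the limit of > 50000 nM in this assay, at which 1 of the 3 values shown sits, so the true size of that step is not known. Compound 4 is therefore estimated at 9000 nM in this assay.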

Compound 4, half-maximal inhibitory concentration: 12800 nM
Compound 4: the middle estimate sits 1.4-fold (0.15 log units) below what was measured; measured number inside the range.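

On the core of compound 3 in this assay, the change from but-1-en-1-yl to pent-1-en-1-yl brought a 2.1-fold lower number from compound 3 to compound 4 (0.33 log units; beyond the scatter), so the change lowers the number on both cores. This does not show that it carries over with the same size: the same change on two cores in this assay, an at least 2.9-fold lower number (0.46 log units; beyond the scatter) from compound 1 to compound 2 and a 2.1-fold lower number (0.33 log units; beyond the scatter) from compound 3 to compound 4; the limit leaves it open whether they differ With the pent-1-en-1-yl chain in place, the swap to 4-methoxyphenyl gave a 1.3-fold lower number from compound 2 to compound 4 (0.12 log units; within the scatter), and how this compares with the same swap on the shorter chain cannot be settled: the same change on two cores in this assay, an at least 1.8-fold lower number (0.26 log units; that floor lies within the scatter) from compound 1 to compound 3 and a 1.3-fold lower number (0.12 log units; within the scatter) from compound 2 to compound 4; the limit leaves it open whether they differ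

The compounds shown leave open whether a longer chain, such as hex-1-en-1-yl, would lower the number again on either core. They also leave open what an amine at the end of the chain would do.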